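The compounds below may be only part of what the source reports. "The series", "measured", "known", "first", "only" and "open" are said of these compounds alone.

Compound 1, `Cc1cccc(C)c1OC(C)C1=NCCN1` — 182 nM
Compound 2, `CC(Oc1ccccc1Br)C1=NCCN1` — 355 nM
Compound 3, `C=CCc1cccc(CC=C)c1OC(C)C1=NCCN1` — 275 nM

Of the compounds shown here, three share a core and have been measured in an assay on CHO cells for displacement of a labelled ligand from Alpha-2B adrenergic receptor (Homo sapiens); on this read-out lower numbers stand for stronger inhibition and higher numbers for weaker inhibition. Compound 1 gives 182 nM, compound 3 gives 275 nM and compound 2 gives 355 nM. Compound 2 carries the highest number of the three, yet its gap to compound 3 and its gap to compound 1 both lie within the usual scatter of such measurements, so the three cannot be told apart on these numbers.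

Compound 4, `CC(Oc1ccccc1S(C)(=O)=O)C1=NCCN1`, has not yet been measured in this assay. It differs from compound 2 in one place: methylsulfonyl in place of bromo on an aromatic carbon. Within the data shown here, no pair of measured compounds shows a change of this kind, so the expectation for compound 4 rests on the three values alone and on the nature of the change. The step from bromo to methylsulfonyl is a large one in the group itself, and it is expected to carry the number in this assay upward, that is toward weaker inhibition, beyond the scatter. The step expected from compound 2 to compound 4 is a 4.2-fold higher number from compound 2 to compound 4 (0.63 log units; beyond the scatter). For compound 4 the estimated value in this assay is 1500 nM, with a range from 400 nM to 6000 nM.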

Compound 4, inhibition constant: 51300 nM
For compound 4 the middle estimate is 34-fold (1.53 log units) below the measured one, outside the stated range (above it).
By their numbers in this assay, from the lowest: compounds 1, 3 and 2 (each within the scatter of the next); then compound 4.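

In this assay, among these compounds, methylsulfonyl in place of bromo on an aromatic carbon gives a 140-fold higher number from compound 2 to compound 4 (2.16 log units; beyond the scatter), the first step between two measured compounds that differ in one place. The three earlier values could not be told apart, and no single change could be read from them, so they gave no sign of how much this position could move the number. This step shows that a change on this aromatic carbon, ortho to a group of 8 heavy atoms, can carry the number far toward weaker inhibition, at least when one bromine atom is replaced by methylsulfonyl, with its 4 heavy atoms and 2 hydrogen-bond acceptors.

With only this one change, the compounds shown leave open whether the count of heavy atoms or the hydrogen-bond acceptors goes with the step, and whether methoxy, an amine or a nitrile on the same carbon would stay close to compound 2 or move as far as compound 4. Nothing at hand gives a reason for the size of this step.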